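Methoxyphenyl isomers and a 3-hydroxyphenyl step

The source may report more compounds than this note shows. Statements on the series, on what has been measured and on what is new or still open speak of the compounds shown alone.

Compound 1 `COc1ccccc1/C=C1\CCC/C(=C\c2ccc(OC)c(OC)c2)C1=O`, compound 2 `COc1cccc(/C=C2\CCC/C(=C\c3ccc(OC)c(OC)c3)C2=O)c1` and compound 3 `COc1ccc(/C=C2\CCC/C(=C\c3ccc(OC)c(OC)c3)C2=O)cc1` differ only in whether a 2-methoxyphenyl, 3-methoxyphenyl or 4-methoxyphenyl group sits on the shared core. In a functional assay on A549 cells (Homo sapiens) for cytotoxicity, read by MTT assay, with a stated time of 72 h (a higher number here means a weaker inhibitor, a lower number a stronger inhibitor), compound 3 gives > 20000 nM, which is a limit of the assay and not a number. Compound 1 gives > 20000 nM, also a limit. Going by the values given here, compound 2 gives 6700 nM, the only true number of the three. Among the compounds with values here, the series so far therefore stands at the limit of > 20000 nM in this assay, at which 2 of the 3 values shown sit.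

Compound 4 `COc1ccc(/C=C2\CCC/C(=C\c3cccc(O)c3)C2=O)cc1OC` is the next step: 3-hydroxyphenyl in place of 4-methoxyphenyl on a double-bonded chain carbon bound to a double-bonded ring carbon. It carries 3-hydroxyphenyl in place of 4-methoxyphenyl on a double-bonded chain carbon bound to a double-bonded ring carbon.

Within the data shown here, two measured steps bear on this change: an at least 2.9-fold lower number from compound 1 to compound 2 (0.47 log units; beyond the scatter) and an at least 2.9-fold higher number from compound 2 to compound 3 (0.47 log units; beyond the scatter). Among the measured compounds shown here, both favour the 3-methoxyphenyl group, though no measured step covers hydroxyl in place of methoxy. The expectation rests on the shared 3-substitution with compound 2 at 6700 nM, so a modest move to a lower number is expected. A real chance remains that compound 4 stays at the limit of the assay. The estimated step is an at least 2.8-fold lower number from compound 3 to compound 4 (0.45 log units; beyond the scatter). For compound 4 the expected value is 7000 nM, with an estimated range of 2500 nM to 20000 nM.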

Compound 4, half-maximal inhibitory concentration: 4300 nM
Compound 4: middle estimate off by 1.6-fold (0.21 log units), on the high side; measured number inside the range.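

In this assay, 3-hydroxyphenyl on a double-bonded chain carbon bound to a double-bonded ring carbon gives a true number where 4-methoxyphenyl and 2-methoxyphenyl gave only limits, with an at least 4.6-fold lower number from compound 3 to compound 4 (0.66 log units; beyond the scatter) and an at least 4.6-fold lower number from compound 1 to compound 4 (0.66 log units; beyond the scatter). The new comparison at this position is hydrogen in place of methyl on an oxygen on an aromatic ring, and it stays within the scatter, with a 1.6-fold lower number from compound 2 to compound 4 (0.19 log units; within the scatter), so the two groups cannot be told apart in this assay. The two compounds with true numbers, compound 2 and compound 4, both carry a 3-substituted phenyl group, while the 2-methoxyphenyl and 4-methoxyphenyl compounds remain at the limit: the limit of > 20000 nM in this assay, at which 2 of the 4 values shown sit.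

The compounds shown leave open whether an oxygen is needed on the 3-substituted phenyl group at all; an amine or a carboxylic acid in that place, or a longer chain on the oxygen, would test this. Going by these compounds, the full size of the steps from compound 1 and compound 3 also remains open, as each starts from a limit and not from a number.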